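From hydroxy to isopropoxy on compound 2

This account rests on a few compounds, and the source may have more. Where it says the series, first, only, none or still open, it means among the compounds named here.

- Compound 1 `CC1=C2CC(C)(C)/C=C/C(=O)/C(C)=C\C3=C[C@H](C)C[C@]3(O2)[C@]1(C)O` gives 26000 nM
- Compound 2 `C/C1=C/C2=C[C@H](C)C[C@@]23O[C@]2(CC(C)(C)[C@@H](O)[C@@H]2C1=O)[C@@H](C)C3=O` gives 10400 nM

Of these two compounds, compound 2 has the lower number in an ADME assay on BJ cells (Homo sapiens) for cytotoxicity, read by CellTiter-Glo, with a stated time of 72 h (on this read-out higher numbers stand for an effect only at larger amounts of compound and lower numbers for an effect already at smaller amounts), and its gap to compound 1 lies beyond the usual scatter. Compound 3 `C/C1=C/C2=C[C@H](C)C[C@@]23O[C@]2(CC(C)(C)[C@@H](OC(C)C)[C@@H]2C1=O)[C@@H](C)C3=O` is not yet measured. The change isopropyl in place of hydrogen on an oxygen on a saturated carbon puts isopropyl in place of hydrogen on an oxygen on a saturated carbon, so hydroxy becomes isopropoxy. Among the measured compounds shown here, no measured pair shows this change, which leaves little to go on. The expected step of a 1.2-fold higher number from compound 2 to compound 3 (0.06 log units; within the scatter) stays within the usual scatter, with no firm direction. Compound 3 is estimated at 12000 nM (expected range 4000 nM to 35000 nM).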

Compound 3, half-maximal effective concentration: 26000 nM
For compound 3 the middle estimate is 2.2-fold (0.34 log units) below the measured one; measured number inside the range.
By their numbers in this assay, from the lowest: compound 2; then compounds 1 and 3 (each within the scatter of the next).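

In this assay, replacing the hydrogen of the hydroxy with isopropyl gives a 2.5-fold higher number from compound 2 to compound 3 (0.40 log units; beyond the scatter). Among the compounds shown here, this is the first sign that a change on this oxygen on a saturated carbon can shift the number beyond the usual scatter, although it rests on a single pair. Nothing measured here offers a reason for the step. On these data alone, whether a methoxy or an ethoxy at this place would stay close to compound 2 or move towards compound 3 remains open, as does the outcome with an amine in place of the hydroxy.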